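This account rests on a few compounds, and the source may have more. Where it says the series, first, only, none or still open, it means among the compounds named here.

Compounds measured in a physicochemical assay for lipophilicity, read by HPLC, in phosphate buffer, measured as octanol-water partition, with a stated time of 1 h, at pH 7.4; on this read-out higher numbers stand for higher lipophilicity and lower numbers for lower lipophilicity:
compound 1 `C[C@@]1(c2cc(NC(=O)c3ncc(OCF)nc3N)ccc2F)C=C(CF)OC(N)=N1` — compound 1 gives 3.1
compound 2 `C[C@@]1(c2cc(NC(=O)c3cnc(OCF)cn3)ccc2F)C=C(CF)OC(N)=N1` — compound 2 gives 2.6
compound 3 `COc1cnc(C(=O)Nc2ccc(F)c([C@]3(C)C=C(CF)OC(N)=N3)c2)cn1` — compound 3 gives 2.7

Among these three, compound 1 stands highest in this assay: the nearest neighbour is compound 3, and the step of a number 0.40 log units lower from compound 1 to compound 3 (beyond the scatter) lies beyond the scatter, while the step of a number 0.50 log units lower from compound 1 to compound 2 (beyond the scatter) is the largest of the set. The step of a number 0.10 log units higher from compound 2 to compound 3 (within the scatter) is within the scatter, so compounds 2 and 3 cannot be told apart here.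

Compound 4 `Cc1cc(C#N)cnc1C(=O)Nc1ccc(F)c([C@]2(C)C=C(CF)OC(N)=N2)c1` has not yet been measured. It differs from compound 1 as follows: 5-cyano-3-methylpyridin-2-yl in place of 3-amino-5-(fluoromethoxy)pyrazin-2-yl on a carbonyl carbon. Two of the measured steps bear on this change. The step of a number 0.50 log units lower from compound 1 to compound 2 (beyond the scatter) shows what the loss of the amino group alone did, and the step of a number 0.40 log units lower from compound 1 to compound 3 (beyond the scatter) shows what exchanging the whole group on the carbonyl carbon for another did; both point downward by a modest amount. Going by the values given here, no measured compound carries the 5-cyano-3-methylpyridin-2-yl group, so the data give no direct guide to it. Compound 4 is therefore expected to fall a little below compound 1, with a step of a number 0.20 log units lower from compound 1 to compound 4 (within the scatter) that is estimated to stay within the scatter or just beyond it. The value of compound 4 in this assay is estimated at 2.9, with a range from 2.4 to 3.4.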

Compound 4, distribution coefficient: 2.5
Compound 4: middle estimate off by 0.40 log units, on the high side; measured number inside the range.
By their numbers in this assay, from the lowest: compounds 4, 2 and 3 (each within the scatter of the next); then compound 1.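

In this assay, the exchange of 3-amino-5-(fluoromethoxy)pyrazin-2-yl for 5-cyano-3-methylpyridin-2-yl on the carbonyl carbon gives a number 0.60 log units lower from compound 1 to compound 4 (beyond the scatter), so a group with a different ring, a nitrile and a methyl also fails to hold the level of compound 1. Against the two pyrazinyl groups that carry no amino substituent, the exchange gives a number 0.20 log units lower from compound 3 to compound 4 (within the scatter) and a number 0.10 log units lower from compound 2 to compound 4 (within the scatter), which places the new group level with both. Among these four compounds, three different groups on the carbonyl carbon therefore cannot be told apart, and only compound 1, the one compound with an amino group there, stands clear of the rest.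

Nothing shown gives a measured reason for this grouping. The compounds shown leave open whether an amino group added to the 5-cyano-3-methylpyridin-2-yl group would bring the number back towards that of compound 1, what the nitrile and the methyl each contribute alone, and where a group such as ethoxy or a carboxylic acid on the same ring would fall.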